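This account rests on a few compounds, and the source may have more. Where it says the series, first, only, none or still open, it means among the compounds named here.

Measured so far, in a functional assay on MKN-74 cells (Homo sapiens) for antiproliferative activity, with a stated time of 24 h; a higher number here means a weaker inhibitor, a lower number a stronger inhibitor:

- compound 1, `NC(=O)c1c(NC(=O)c2ccccc2Cl)sc2c1CCN(C(=S)Nc1ccccc1)C2`, gives 15600 nM
- compound 2, `NC(=O)c1c(NC(=O)c2ccccc2Cl)sc2c1CCN(C(=S)Nc1ccccc1F)C2`, gives 12600 nM
- compound 3, `NC(=O)c1c(NC(=O)c2ccccc2)sc2c1CCN(C(=S)Nc1ccccc1Cl)C2`, gives 11800 nM

All three numbers lie close together, and none of the gaps between them goes beyond the scatter of repeated measurements, so no one of them can be called stronger or weaker than another.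

Compound 1 and compound 2 differ in one place: fluoro in place of hydrogen on an aromatic carbon. In this assay that change gave a 1.2-fold lower number from compound 1 to compound 2 (0.09 log units; within the scatter). Compound 1 and compound 3 have the same atoms joined differently, and the difference between the two cores is not broken down here.

Compound 4, `NC(=O)c1c(NC(=O)c2ccccc2F)sc2c1CCN(C(=S)Nc1ccccc1Cl)C2`, has not yet been measured. It differs from compound 3 by fluoro in place of hydrogen on an aromatic carbon. Within the data shown here, this is the same kind of change as the one from compound 1 to compound 2, made on the ring read as benzamido rather than on the ring read as anilino.

For compound 4 the step from compound 3 is expected to be a 1.1-fold lower number from compound 3 to compound 4 (0.03 log units; within the scatter), a step that is expected to stay within the scatter because the same kind of change gave a 1.2-fold lower number from compound 1 to compound 2 (0.09 log units; within the scatter). On that basis compound 4 is expected to give about 11000 nM in this assay, most likely between 6000 nM and 20000 nM.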

Compound 4, half-maximal inhibitory concentration: 11100 nM
Compound 4: middle estimate off by 1.0-fold (0.00 log units), on the low side, and the stated range covers the measured number.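

In this assay, fluoro in place of hydrogen on an aromatic carbon gave a 1.1-fold lower number from compound 3 to compound 4 (0.03 log units; within the scatter) and the comparison with the earlier case of this change shows that the two steps agree: the same change on two cores in this assay, a 1.2-fold lower number (0.09 log units; within the scatter) from compound 1 to compound 2 and a 1.1-fold lower number (0.03 log units; within the scatter) from compound 3 to compound 4, 1.2-fold (0.07 log units) apart, within the scatter of two such steps. On both cores, then, the change produced no step beyond the scatter, and in that limited sense its outcome carried from the core of compound 1 to the core of compound 3, even though fluoro enters the ring read as anilino in the first pair and the ring read as benzamido in the second. This does not show that fluoro has a real effect of a fixed size that can be transferred, since steps this small cannot be told apart from repeated measurement of a single compound, and two pairs say nothing about any other core.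

The compounds shown leave open whether a larger group on these rings, such as methoxy, trifluoromethyl or an amine, would give a step that stands clear of the scatter. They also leave open whether a change elsewhere, for example replacing the primary amide with a nitrile or a carboxylic acid, would do so.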